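This account rests on a few compounds, and the source may have more. Where it says the series, first, only, none or still open, it means among the compounds named here.

Working notes on the series. In an assay on HEK293 cells for displacement of a labelled ligand from Melanocortin receptor 4 (Homo sapiens) (a lower number here means a stronger inhibitor, a higher number a weaker inhibitor), compound 1 `CCCCC(N)c1cc(C(F)(F)F)ccc1N1CCN(C(=O)CCc2ccc(Cl)cc2Cl)CC1` gives 190 nM. Compound 2 `CCC(C)[C@H](N)c1cc(C(F)(F)F)ccc1N1CCN(C(=O)CCc2ccc(OC)c(OC)c2Cl)CC1` gives 2500 nM in this assay, and compound 3 `CC(C)C[C@H](N)c1cc(C(F)(F)F)ccc1N1CCN(C(=O)CCc2ccccc2O)CC1` gives 3300 nM. Compound 3 therefore carries the highest of the three numbers; its value and that of compound 2 lie within the scatter of each other, whereas compound 1 sits at a much lower number, a gap that is beyond the scatter.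

Compound 4 `CC(C)C[C@H](N)c1cc(C(F)(F)F)ccc1N1CCN(C(=O)CCc2ccc(O)cc2)CC1` differs from compound 3 in a single place: 4-hydroxyphenyl in place of 2-hydroxyphenyl on a saturated chain carbon, two bonds along the chain from a carbonyl carbon. Among the compounds with values here, no measured pair in this set shows this change, so its effect can only be judged from the fact that the same atoms are kept and only rejoined. On that basis the step is expected to be small in this assay, with no clear direction, and to stay within the usual scatter. The step that the estimate implies is a 1.1-fold lower number from compound 3 to compound 4 (0.04 log units; within the scatter), expected to be unremarkable. Compound 4 is accordingly estimated at 3000 nM, with a range from 1000 nM to 9000 nM.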

Compound 4, inhibition constant: > 10000 nM
Compound 4: no number, only a limit; the forecaster's own chance of this, stated with the estimate: 10%; middle value at least 3.3-fold (0.52 log units) away from the limit.
By their numbers in this assay, from the lowest: compound 1; then compounds 2 and 3 (each within the scatter of the next). At a limit, above all of these: compound 4.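

Exchanging 2-hydroxyphenyl for 4-hydroxyphenyl on a saturated chain carbon, two bonds along the chain from a carbonyl carbon, is not a neutral change in this assay, even with the same atoms simply rejoined: the data show an at least 3.0-fold higher number from compound 3 to compound 4 (0.48 log units; beyond the scatter). Compound 4 reads > 10000 nM, which is a limit of the assay and not a number, so the direction of the step is fixed but its full size is not. The earlier compounds offered no pair differing in one place, so this is the first single change read in the series, and it rests on a value at the end of the range: the limit of > 10000 nM in this assay, at which 1 of the 4 values shown sits.

On these data alone, whether an unsubstituted phenyl or a carboxylic acid in place of the hydroxyl would be tolerated at this position remains open. Also open, as far as these compounds go, is whether the same step would appear with a different amine-bearing side chain on the core.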